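Working notes: 4-hydroxyphenyl series, phenyl in place of thiophene

The source may hold more compounds than are shown below. What is called first, only, known or untested is meant among the compounds shown, and "the series" means these compounds.

Measured so far:
compound 1 `Oc1ccc(-c2cc(-c3ccccc3)nc(-c3ccccc3Cl)c2)cc1` gives 4990 nM
compound 2 `Oc1ccc(-c2cc(-c3ccc(Cl)cc3)nc(-c3cccs3)c2)cc1` gives 6470 nM
compound 3 `Oc1ccc(-c2cc(-c3ccc(Cl)cc3)nc(-c3ccsc3)c2)cc1` gives 6240 nM

All three numbers come from a functional assay on HCT-15 cells (Homo sapiens) for cytotoxicity, read by CCK-8 assay and cell counting, with a stated time of 2 days; on this read-out higher numbers stand for weaker inhibition and lower numbers for stronger inhibition. Compound 3 stands second highest of the three; its nearest neighbour is compound 2 and its furthest is compound 1, and both sit within the scatter of it, so no order among the three can be claimed.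

Compound 4 `Oc1ccc(-c2cc(-c3ccccc3)nc(-c3ccc(Cl)cc3)c2)cc1` is the next member. Relative to compound 3 the change is phenyl in place of thiophen-3-yl on an aromatic carbon.

Of the measured steps only a 1.0-fold lower number from compound 2 to compound 3 (0.02 log units; within the scatter) touches the same position, and it lay within the scatter. For the measured compounds named here, compound 1 also carries a phenyl on the shared core but differs from compound 4 in a second place too, so its value shows only that a phenyl-bearing member falls in the same band as compounds 2 and 3. Going by the values given here, no measured step exchanges a five-membered ring for a six-membered one, so the direction of this change cannot be read from the data. Among the compounds with values here, because the only step at this position, a 1.0-fold lower number from compound 2 to compound 3 (0.02 log units; within the scatter), stays within the scatter, the expected step of a 1.1-fold lower number from compound 3 to compound 4 (0.05 log units; within the scatter) is none beyond the scatter. Compound 4 is therefore estimated at 5600 nM in this assay, with a range of 2500 nM to 12500 nM.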

Compound 4, half-maximal inhibitory concentration: 6920 nM
Compound 4: the middle estimate sits 1.2-fold (0.09 log units) below what was measured, within the range that was stated.
By their numbers in this assay, from the lowest: compounds 1, 3, 2 and 4 (each within the scatter of the next).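

In this assay, the phenyl ring on the aromatic carbon next to the ring nitrogen gives a 1.1-fold higher number from compound 3 to compound 4 (0.04 log units; within the scatter) when it enters for thiophen-3-yl, and a 1.1-fold higher number from compound 2 to compound 4 (0.03 log units; within the scatter) when it enters for thiophen-2-yl. At this place, then, the exchange of a five-membered aromatic ring with one hetero atom for a six-membered aromatic ring of carbon only leaves the number in the same band, a comparison the earlier thiophene pair could not offer. The change from 2-chlorophenyl to 4-chlorophenyl gives a 1.4-fold higher number from compound 1 to compound 4 (0.14 log units; within the scatter) on the same read-out, so the two chlorophenyl isomers are also not told apart here. Nothing at hand on these compounds offers a reason for this flat result.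

As far as these compounds go, all the aromatic rings seen at this place are uncharged, so whether an aminomethyl group, a carboxylic acid or a longer alkyl chain here would produce a step beyond the scatter remains open. All four compounds also carry the 4-hydroxyphenyl group, which leaves open what a methoxy group or an amine in place of its hydroxyl would do to the number.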